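A few compounds are considered here, and "the series" means these few. Any claim that something is new, unique, unknown or untested is made for them only; others in the source may bear on it.

Measured so far:
Compound 1 `C=CCOC(=O)Nc1ccc([Se]C#N)cc1`, which in a functional assay on HTB-54 cells (Homo sapiens) for cytotoxicity, read by MTT assay, with a stated time of 72 h (a higher number here means a weaker inhibitor of growth, a lower number a stronger inhibitor of growth), gives 27000 nM.
Compound 2 `N#C[Se]c1ccc(NC(=O)OCc2ccc([N+](=O)[O-])cc2)cc1`, which in this assay gives 22900 nM.

Compound 2 holds the lower of the two numbers, but its gap to compound 1 lies within the scatter, so the two cannot be told apart. The step to compound 3 `N#C[Se]c1ccc(NC(=O)OCc2ccccc2)cc1` is hydrogen in place of nitro on an aromatic carbon. Within the data shown here, no measured pair shows the size of such a step. Because compound 1 gives 27000 nM and compound 2 gives 22900 nM, the account expects no step beyond the scatter in this assay. The expected step is a 1.1-fold higher number from compound 2 to compound 3 (0.04 log units; within the scatter). Compound 3 is therefore estimated at 25000 nM, within a range from 10000 nM to 60000 nM.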

Compound 3, concentration for 50% growth inhibition: 27600 nM
Compound 3: middle estimate off by 1.1-fold (0.04 log units), on the low side; low and high end bracket the measured number.
By their numbers in this assay, from the lowest: compounds 2, 1 and 3 (each within the scatter of the next).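

Hydrogen in place of nitro on an aromatic carbon gives a 1.2-fold higher number from compound 2 to compound 3 (0.08 log units; within the scatter) in this assay, the first direct reading at this position. Phenyl in place of vinyl on a saturated chain carbon bound to an oxygen next to a carbonyl group gives a 1.0-fold higher number from compound 1 to compound 3 (0.01 log units; within the scatter), so neither exchange can be told from no step. Nothing measured here speaks to the reason for these results.

From the compounds shown here alone, whether an amine or a carboxylic acid on that aromatic carbon would give a step beyond the scatter remains open. So does the effect of a longer chain in place of vinyl.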